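The compounds below may be only part of what the source reports. "The series", "measured", "known", "first", "only" and "open" are said of these compounds alone.

Working notes on the series. In a functional assay on KB cells (Homo sapiens) for inhibition, read by sulforhodamine B assay, with a stated time of 72 h (a higher number here means a weaker inhibitor of growth, a lower number a stronger inhibitor of growth), compound 1 (`CNC(=O)/C=C/c1ccncc1-c1ccc2ccccc2c1`) gives > 10000 nM, which is a limit and not a number. Compound 2 (`CNC(=O)/C=C/c1ccncc1-c1ccc2cc[nH]c2c1`) gives > 10000 nM, also a limit. Compound 1 therefore stands at the limit of > 10000 nM in this assay, at which 2 of the 2 values shown sit. Compound 3 (`CNC(=O)CCc1ccncc1-c1ccc2ccccc2c1`) carries 2-(methylcarbamoyl)ethyl in place of 2-(methylcarbamoyl)ethenyl on an aromatic carbon, opposite the ring nitrogen: 2-(methylcarbamoyl)ethyl in place of 2-(methylcarbamoyl)ethenyl on an aromatic carbon. Among the compounds with values here, no measured step covers this change, so the expected step is a step that the limit leaves unreadable from compound 1 to compound 3, with nothing beyond the scatter and no firm direction. For compound 3 the estimated value is 12000 nM, expected between 5000 nM and 30000 nM, and probably reported as a limit again.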

Compound 3, concentration for 50% growth inhibition: > 10000 nM
Compound 3 ended at the assay's limit (the forecaster's own chance of this, stated with the estimate: 85%); the middle value is on the limit's open side.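

No step from compound 1 to compound 3 can be read, since both values are limits: the limit of > 10000 nM in this assay, at which 3 of the 3 values shown sit.

The compounds shown leave open what, if anything, on this core gives a measurable value in this assay.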